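A few compounds are considered here, and "the series" means these few. Any claim that something is new, unique, unknown or untested is made for them only; others in the source may bear on it.

Measured in an ADME assay on MDCK cells (Canis lupus familiaris) for cytotoxicity, with a stated time of 48 h; a lower number here means that less compound is tolerated, a higher number that more compound is tolerated:
- Compound 1 `C=C(C(=O)OC)[C@@H]1CC[C@H](C)[C@H]2C(=C(C)C(=O)[C@H]2NC(=O)c2ccccc2)C1`: 84.3 uM
- Compound 2 `C=C(C(=O)OC)[C@@H]1CC[C@H](C)[C@H]2C(=C(C)C(=O)[C@H]2NC(=O)C(C)CCl)C1`: 735 uM
- Compound 3 `C=C(C(=O)OC)[C@@H]1CC[C@H](C)[C@H]2C(=C(C)C(=O)[C@H]2NC(=O)CNC(=O)c2ccccc2)C1`: 488 uM

Compound 3 stands at the upper end of this small set, level within the scatter with its nearest neighbour: a 1.5-fold lower number from compound 2 to compound 3 (0.18 log units; within the scatter). The remaining analogue lies further off: a 5.8-fold higher number from compound 1 to compound 3 (0.76 log units; beyond the scatter).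

The next analogue is compound 4 `C=C(C(=O)OC)[C@@H]1CC[C@H](C)[C@H]2C(=C(C)C(=O)[C@H]2NC(=O)CC#N)C1`, which has cyano in place of benzamido on a saturated chain carbon bound to a carbonyl carbon. The same change can be read as benzamidomethyl to cyanomethyl.

For the measured compounds named here, no measured step makes exactly this change, so the evidence is indirect. The two large steps both start from the phenyl group of compound 1, and the ringless group of compound 2 gave an 8.7-fold higher number from compound 1 to compound 2 (0.94 log units; beyond the scatter). The much larger benzamidomethyl group gave a step of similar reach, a 5.8-fold higher number from compound 1 to compound 3 (0.76 log units; beyond the scatter). The step that compares a ringless group with benzamidomethyl stayed within the scatter, a 1.5-fold lower number from compound 2 to compound 3 (0.18 log units; within the scatter). Cyanomethyl also carries no ring, so no step beyond the scatter is expected in this assay, though three compounds are a thin basis. The expected change is a 1.0-fold higher number from compound 3 to compound 4 (0.01 log units; within the scatter). For compound 4 the estimated value is 500 uM, with an expected range of 220 uM to 1000 uM.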

Compound 4, half-maximal toxic concentration: 1450 uM
Compound 4: middle estimate off by 2.9-fold (0.46 log units), on the low side; the whole stated range lies below it.
By their numbers in this assay, from the lowest: compound 1; then compounds 3, 2 and 4 (each within the scatter of the next, the first and the last beyond it).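

In this assay, for the compounds shown here, the exchange of benzamido for cyano on a saturated chain carbon bound to a carbonyl carbon gives a 3.0-fold higher number from compound 3 to compound 4 (0.47 log units; beyond the scatter), the first step beyond the scatter that does not start from the phenyl group of compound 1. The benzamido part of compound 3 therefore counts at this place, although the earlier comparison with the ringless group of compound 2 had not revealed it. The two ringless groups now stand level, with a 2.0-fold higher number from compound 2 to compound 4 (0.30 log units; within the scatter), while the distance from the phenyl amide widens to a 17-fold higher number from compound 1 to compound 4 (1.24 log units; beyond the scatter), yet compound 3 goes against any simple split by ring, as it carries a ring and remains within the scatter of compound 2. Nothing among the available data accounts for these shifts.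

On these data alone, whether the nitrile itself matters, or whether any small ringless group would give a similar number, stays open. How an amine, a carboxylic acid or a longer chain would behave at this place is also unknown from the compounds shown here.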